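From an Azetidine Amide to an Ethyl Ester

The source may report more compounds than this note shows. Statements on the series, on what has been measured and on what is new or still open speak of the compounds shown alone.

Of the compounds shown here, two have been tested in a functional assay on A549 cells (Homo sapiens) for inhibition, read by sulforhodamine B assay, with a stated time of 72 h; on this read-out lower numbers stand for stronger inhibition of growth and higher numbers for weaker inhibition of growth. Compound 1, `COC1CN(C(=O)/C=C/c2ccncc2-c2ccc3ccccc3c2)C1`, gives in this assay > 10000 nM, which is a limit of the assay rather than a measured number. Compound 2, `Cn1ncc2cc(-c3cnccc3/C=C/C(=O)O)ccc21`, gives in this assay > 10000 nM, again a limit and not a number. Going by the values given here, both values sit at the same limit, so compound 1 cannot be placed above or below compound 2, and no step between measured compounds can be counted; the limit of > 10000 nM in this assay, at which 2 of the 2 values shown sit, is all that the numbers offer.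

Compound 3, `CCOC(=O)/C=C/c1ccncc1-c1ccc2ccccc2c1`, has not yet been measured. It differs from compound 1 in one place: ethoxy in place of 3-methoxyazetidin-1-yl on a carbonyl carbon. Nothing measured here shows how much such a change matters. Because compound 1 gives > 10000 nM in this assay, there is no number from which a step could be read. The step is therefore estimated as a step that the limit leaves unreadable from compound 1 to compound 3, that is, none beyond the usual scatter. Compound 3 is expected to give about 15000 nM, within a range from 3000 nM to 60000 nM, and most likely only a limit once more.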

Compound 3, concentration for 50% growth inhibition: 5380 nM
Estimate against measurement, compound 3: 2.8-fold (0.45 log units) above; low and high end bracket the measured number.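

Going by these compounds alone, compound 3 brings the first real number to this series: in this assay compound 3 gives 5380 nM, so the group on this carbonyl carbon now has a measured point for later comparisons. Putting ethoxy in place of 3-methoxyazetidin-1-yl gives an at least 1.8-fold lower number from compound 1 to compound 3 (0.26 log units; that floor lies within the scatter), which means that this change can be seen to bring the value inside the measured range, although the printed floor of the step alone does not establish a difference larger than ordinary repeat variation. The numbers now show where the series stands against its limit, which still holds the other two compounds: the limit of > 10000 nM in this assay, at which 2 of the 3 values shown sit.

As far as these compounds go, the true size of the step stays unknown, since only its floor can be read, and so does the question of whether ethoxy itself matters or whether the 3-methoxyazetidin-1-yl group is simply a poor fit for this position. A longer chain such as butoxy, or a small amine such as dimethylamino, on the same carbonyl carbon would show whether the value follows the kind of group placed there.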